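Adding a Chloro Group to the Core of Compound 1

The source may hold more compounds than are shown below. What is called first, only, known or untested is meant among the compounds shown, and "the series" means these compounds.

Compound 1 `[O-][S+](CCC(F)(Cl)C(F)(F)Cl)c1nc2ccccc2s1` holds the higher of the two numbers recorded so far: in a functional assay on HepG2 cells (Homo sapiens) for cytotoxicity, read by MTT assay, with a stated time of 48 h (a lower number here means a stronger inhibitor, a higher number a weaker inhibitor), compound 1 gives 13500 nM. Compound 2 `O=S(=O)(CCC(F)(Cl)C(F)(F)Cl)c1nc2ccccc2s1` gives 4500 nM in this assay, a lower number that lies beyond the usual scatter. Compound 3 `[O-][S+](CCC(F)(Cl)C(F)(F)Cl)c1nc2ccc(Cl)cc2s1` is still unmeasured; it differs from compound 1 by chloro in place of hydrogen on an aromatic carbon, a chloro in place of hydrogen on an aromatic carbon. Among the compounds with values here, no measured pair shows what this change does. For compound 3 a modest downward step a 1.5-fold lower number from compound 1 to compound 3 (0.18 log units; within the scatter) is expected, hardly beyond the scatter. Compound 3 is estimated at 9000 nM, within a range from 3000 nM to 27000 nM.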

Compound 3, half-maximal inhibitory concentration: 6900 nM
Compound 3: middle estimate off by 1.3-fold (0.12 log units), on the high side; measured number inside the range.
By their numbers in this assay, from the lowest: compounds 2, 3 and 1 (each within the scatter of the next, the first and the last beyond it).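

In this assay, within the data shown here, chloro in place of hydrogen on an aromatic carbon, meta to a fused ring and para to a fused ring, gives the first measured step for this change, a 2.0-fold lower number from compound 1 to compound 3 (0.29 log units; within the scatter). The position therefore takes a chloro without a shift that stands clear of the scatter. No available measurement gives a reason for this step. On these data alone, whether a methoxy group, an amine or a carboxylic acid on this carbon would shift the number more remains open. So does what the same chloro would do on compound 2.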